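This account rests on a few compounds, and the source may have more. Where it says the series, first, only, none or still open, it means among the compounds named here.

Working notes on the series. In a functional assay on A549 cells (Homo sapiens) for antiproliferative activity, read by MTT assay, with a stated time of 48 h (on this read-out lower numbers stand for stronger inhibition and higher numbers for weaker inhibition), compound 1 `O=C1Nc2ccccc2[C@]12N[C@H](c1ccccc1)[C@H](c1ccccc1)[C@@]21CCc2c([nH]c3ccc(Cl)cc23)C1=O` gives 15000 nM. Compound 2 `Cc1ccc2[nH]c3c(c2c1)CC[C@]1(C3=O)[C@@H](c2cccs2)[C@@H](c2ccccc2)N[C@@]12C(=O)Nc1ccccc12` gives 15000 nM in this assay and therefore stands level with compound 1 at the digits recorded; the two values sit within the scatter of each other, so no order between them can be read. Compound 3 `O=C1Nc2ccccc2[C@]12N[C@H](c1ccccc1)[C@H](c1cccs1)[C@@]21CCc2c([nH]c3ccc(Cl)cc23)C1=O` is the next member to be measured in this assay. It differs from compound 2 by a single exchange: chloro in place of methyl on an aromatic carbon. Within the data shown here, no measured pair yet isolates this exchange, so the only guide is that the two compounds measured so far sit at the same level of this assay. On that basis no step beyond the scatter is expected in either direction for compound 3. The expected value for compound 3 in this assay is 15000 nM, with a range of 7000 nM to 32000 nM, which corresponds to an expected step of no change at the digits printed from compound 2 to compound 3 (within the scatter).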

Compound 3, half-maximal inhibitory concentration: 14000 nM
For compound 3 the middle estimate is 1.1-fold (0.03 log units) above the measured one, and the stated range covers the measured number.
By their numbers in this assay, from the lowest: compounds 3, 1 and 2 (each within the scatter of the next).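

In this assay, among these compounds, chloro in place of methyl on an aromatic carbon, meta to a fused ring and para to a fused ring, gives a 1.1-fold lower number from compound 2 to compound 3 (0.03 log units; within the scatter) and thus leaves the read-out level in the first pair to isolate this exchange. Among the compounds shown here, with chloro held in place, thiophen-2-yl in place of phenyl on a saturated ring carbon gives a 1.1-fold lower number from compound 1 to compound 3 (0.03 log units; within the scatter) and so shows that this second position, too, brings no separation between the compounds. No measurement on hand bears on why these values stay level.

As far as these compounds go, whether an amine or a carboxylic acid on that aromatic carbon would move the value beyond the scatter remains open. The same holds for a longer alkyl chain in place of phenyl or thiophen-2-yl on the saturated ring carbon.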